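The compounds below may be only part of what the source reports. "The series", "measured", "known", "first", "only" and "open" are said of these compounds alone.

Compound 1 `CC(C)(C)OC(=O)/C=C1/C(=O)Nc2ccccc21` serves as the starting point. In a functional assay on SAOS-2 cells (Homo sapiens) for inhibition, read by CCK-8 assay, with a stated time of 72 h, tested at 20 uM (on this read-out higher numbers stand for more inhibition of growth at the one concentration tested and lower numbers for less inhibition of growth), compound 1 gives 83.3%, the largest of the three numbers shown, although the two others lie within the usual scatter of it. Compound 2 `CC(C)(C)OC(=O)/C=C1/C(=O)N(Cc2ccccc2)c2ccccc21` carries benzyl in place of hydrogen on an amide-type nitrogen in a ring, and in this assay compound 2 gives 82.1%; the step of a number 1.2 percentage points lower from compound 1 to compound 2 (within the scatter) is within the scatter. Compound 3 `COc1cccc2c1NC(=O)/C2=C/C(=O)OC(C)(C)C` carries methoxy in place of hydrogen on an aromatic carbon, and in this assay compound 3 gives 81.1%; the step of a number 2.2 percentage points lower from compound 1 to compound 3 (within the scatter) is also within the scatter.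

Compound 4 `CC(C)(C)OC(=O)/C=C1/C(=O)Nc2ccc(Cl)cc21` differs from compound 1 by chloro in place of hydrogen on an aromatic carbon. Within the data shown here, of the two measured steps, the one from compound 1 to compound 3 bears most directly on this change, since it too replaces a hydrogen on an aromatic carbon of the shared core, and it left the number essentially unchanged; the benzyl step points the same way. Neither measured change moved the read-out beyond the scatter, so no step beyond the scatter is expected here either, and the estimated change is a number 3.3 percentage points lower from compound 1 to compound 4 (within the scatter). Compound 4 is therefore expected to give about 80% in this assay, within a range from 68% to 90%.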

Compound 4, percent growth inhibition at one concentration: 82.3%
Compound 4: the middle estimate sits 2.3 percentage points below what was measured; measured number inside the range.
By their numbers in this assay, from the lowest: compounds 3, 2, 4 and 1 (each within the scatter of the next).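

In this assay, chloro in place of hydrogen on an aromatic carbon, at the place meta to a fused ring and para to a fused ring, gives a number 1 percentage points lower from compound 1 to compound 4 (within the scatter), so a single chlorine atom at this carbon of the six-membered aromatic ring leaves the read-out where it was. The methoxy change, with a number 2.2 percentage points lower from compound 1 to compound 3 (within the scatter), had tested a different aromatic carbon, so the chloro result extends the picture to a further position on this ring and to a halogen, and here too the number stays within the scatter. Nothing shown gives a reason for this tolerance, and no separate measurement bears on it.

Going by these compounds, all four compounds lie so close together at the one concentration tested that this read-out cannot rank them, and whether they would separate at lower concentrations stays unknown. On these data alone, it also remains open whether a group of a very different kind at this same carbon, such as an amine or a carboxylic acid in place of the chloro, would move the number beyond the scatter.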